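The compounds below may be only part of what the source reports. "The series", "measured", "known", "first", "only" and "open" are said of these compounds alone.

Compound 1 `O=C1N(CCCCCCOc2ccc(Br)cc2)CCN1c1ccncc1` in a functional assay on cells (Homo sapiens) for cytotoxicity (a higher number here means that more compound is tolerated, a lower number that less compound is tolerated), gives > 25000 nM; this is a limit of the assay, not a number. Compound 2 `O=C1N(CCCCCCOc2ccc(C(F)(F)F)cc2)CCN1c1ccncc1` in this assay gives > 25000 nM, again a limit. Among the measured compounds shown here, the only measured step, a step that the two limits leave unreadable from compound 1 to compound 2, therefore cannot be read; what the two values show is that both compounds sit at the limit of > 25000 nM in this assay, at which 2 of the 2 values shown sit. Compound 3 `O=C1N(CCCCCCOc2ccc(Br)cc2)CCN1c1ccncn1` differs from compound 1 by pyrimidin-4-yl in place of pyridin-4-yl on an amide-type nitrogen in a ring. For the measured compounds named here, no measured step touches the pyridin-4-yl group, so nothing on this side of the series bears on the change; the two compounds measured so far both sit at the limit, and the same is the most that can be expected. Compound 3 is expected to give 40000 nM in this assay, within 15000 nM to 120000 nM, and the step is estimated as a step that the limit leaves unreadable from compound 1 to compound 3, most likely reported only as a limit again.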

Compound 3, half-maximal cytotoxic concentration: > 25000 nM
Compound 3: no number, only a limit (the forecaster's own chance of this, stated with the estimate: 80%); the middle value lies beyond the limit too.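

Compound 3 adds no readable step to compound 1, since both values in this assay are limits: the limit of > 25000 nM in this assay, at which 3 of the 3 values shown sit.

The compounds shown leave open how compound 1, compound 2 and compound 3 rank against each other, and at what concentration any of them becomes cytotoxic.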